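The source may hold more compounds than are shown below. What is called first, only, known or untested is meant among the compounds shown, and "the series" means these compounds.

Working notes on the series, measured in a functional assay (thoracic aorta, Rattus norvegicus, strain Wistar); a lower number here means that less compound is needed, a higher number that more compound is needed for the effect.

The shared core carries a urea; the series differs in what hangs on it. Compound 2 `CC(C)NC(=O)Nc1nc2ccccc2s1` gives 35500 nM in this assay. Compound 3 `CCc1ccc2nc(NC(=O)NC(C)C)sc2c1` gives 24400 nM in this assay. The change from compound 2 to compound 3 is ethyl in place of hydrogen on an aromatic carbon, and it makes a 1.5-fold lower number from compound 2 to compound 3 (0.16 log units; within the scatter). Compound 1 `O=C(Nc1nc2ccccc2s1)Nc1ccc(C(F)(F)F)cc1Cl` differs from compound 2 by more than one place, so the difference between the two cores is not broken down here. For compound 1 only a limit is known in this assay, namely > 100000 nM, with the limit of > 100000 nM in this assay, at which 1 of the 3 values shown sits.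

Compound 4 `CCc1ccc2nc(NC(=O)Nc3ccc(C(F)(F)F)cc3Cl)sc2c1` is not yet measured. Its change from compound 1 is ethyl in place of hydrogen on an aromatic carbon, the same change in the same place as that from compound 2 to compound 3. The step is expected to be a number no higher from compound 1 to compound 4 (the limit leaves the size open), resting on the earlier step of a 1.5-fold lower number from compound 2 to compound 3 (0.16 log units; within the scatter) from compound 2 to compound 3, which stayed within the scatter. Compound 4 is therefore estimated at 100000 nM, between 30000 nM and 300000 nM, with a real chance that only a limit is reported again.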

Compound 4, half-maximal effective concentration: > 100000 nM
Compound 4 was reported as a limit (the forecaster's own chance of this, stated with the estimate: 70%); the middle value sits exactly at the limit.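

In this assay, compound 1 and compound 4 are each reported only as a limit, so the step from hydrogen to ethyl on an aromatic carbon cannot be read between them: the limit of > 100000 nM in this assay, at which 2 of the 4 values shown sit.

The compounds shown leave open whether ethyl in place of hydrogen changes the number at all on the core of compound 1.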